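This account rests on a few compounds, and the source may have more. Where it says the series, first, only, none or still open, it means among the compounds named here.

Compound 1 `Cc1ccccc1Nc1nc(Nc2ccc(N3CCN(C)CC3)cn2)ncc1Cl` – 5980 nM
Compound 2 `CCN1CCN(c2ccc(Nc3ncc(Cl)c(Nc4ccccc4C)n3)nc2)CC1` – > 100000 nM (a limit)

Going by the values given here, in an ADME assay on L02 cells (Homo sapiens) for inhibition, read by CCK-8 assay, with a stated time of 48 h (a higher number here means a weaker inhibitor of growth, a lower number a stronger inhibitor of growth), compound 1 gives 5980 nM as the only actual number so far. Compound 2 gives > 100000 nM and that is a limit. Compound 3 `COc1ccccc1CNc1nc(Nc2ccc(N3CCN(C)CC3)cn2)ncc1Cl` departs from compound 1 by the change 2-methoxybenzyl in place of 2-methylphenyl on a nitrogen on an aromatic ring in which 2-methoxybenzyl stands in place of 2-methylphenyl on a nitrogen on an aromatic ring. Among the compounds with values here, the one measured step of an at least 16-fold higher number from compound 1 to compound 2 (1.22 log units; beyond the scatter) is large but sits at a different place, so it bears only loosely on this change. For compound 3 a modest rise in this assay is expected, the estimated step of a 1.7-fold higher number from compound 1 to compound 3 (0.22 log units; within the scatter) being held with wide uncertainty. Compound 3 is estimated at 10000 nM (2500 nM to 50000 nM).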

Compound 3, concentration for 50% growth inhibition: 25500 nM
Estimate against measurement, compound 3: 2.6-fold (0.41 log units) below, within the range that was stated.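

Putting 2-methoxybenzyl in place of 2-methylphenyl on the nitrogen on an aromatic ring gives, in this assay, a 4.3-fold higher number from compound 1 to compound 3 (0.63 log units; beyond the scatter). This shows that the number responds to a change at this position, whereas the earlier step concerned a different place in the molecule. Nothing given here accounts for this rise.

The group changes as a whole, leaving the contribution of the methoxy group apart from that of the benzyl link unresolved. Going by these compounds, how a plain benzyl group or a 2-methoxyphenyl group would read on this nitrogen remains open.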